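This account rests on a few compounds, and the source may have more. Where it says the series, first, only, none or still open, it means among the compounds named here.

Values in a functional assay for antagonist activity, with Cavia porcellus as the target; on this read-out lower numbers stand for stronger inhibition and higher numbers for weaker inhibition:
- compound 1 `CCN(C)CC#CCCC1SCCCS1`: > 10000000 nM
- compound 2 `CCN(CC)CC#CCCC1(C(O)(c2ccccc2)c2ccccc2)SCCCS1`: 500 nM; 500 nM (2 entries)
- compound 3 `CN(CC#CCCC1(C(O)(c2ccccc2)c2ccccc2)SCCCS1)Cc1ccccc1`: 3170 nM

The entry for compound 1 is a limit of the assay and not a number: > 10000000 nM is all that is reported.

Compound 3 reads 3170 nM in a single entry, which is weaker inhibition than compound 2 shows at 500 nM; 500 nM (2 entries) in this assay.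

Compound 4 `CCN(C)CC#CCCC1(C(O)(c2ccccc2)c2ccccc2)SCCCS1` has not yet been measured. It follows from compound 3 by one change: methyl in place of phenyl on a saturated chain carbon bound to an amine nitrogen.

Among the compounds with values here, no measured pair shows this change, so its size remains a judgement. The expectation leans on compound 2 at 500 nM; 500 nM (2 entries) as the closer guide.

An expected step of a 5.8-fold lower number from compound 3 to compound 4 (0.76 log units; beyond the scatter) points toward stronger inhibition and lies beyond the usual scatter.

For compound 4 the estimated value is 550 nM, with an expected range of 180 nM to 1700 nM in this assay.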

Compound 4, antagonist equilibrium constant: 1230 nM
Beside the measured number, compound 4's estimate is 2.2-fold (0.35 log units) below it, within the range that was stated.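

Going from benzyl to ethyl on the amine nitrogen gives, in this assay, a 2.6-fold lower number from compound 3 to compound 4 (0.41 log units; beyond the scatter) and is the first reading of a one-place change in the series: at this position the phenyl is not required for activity, and removing it brings a modest gain. It also makes the amine substituents comparable, since with ethyl in place of the methyl of compound 4, compound 2 reads 500 nM; 500 nM (2 entries) while compound 4 reads 1230 nM in the same assay. Nothing measured for these compounds accounts for the step.

As far as these compounds go, whether a propyl group or a ring amine such as piperidine on the nitrogen would continue this trend remains open. From the compounds shown here alone, the benzyl-to-ethyl change also rests on a single pair, so its size on another amine substituent is unknown.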